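The source may hold more compounds than are shown below. What is called first, only, known or untested is meant among the compounds shown, and "the series" means these compounds.

In a functional assay on a cell-free system (plasma, Homo sapiens) for inhibition, with Plasma (Rattus norvegicus) as the target (a lower number here means a stronger inhibitor, a higher number a weaker inhibitor), three compounds that share one core have been measured. Compound 1 `O=c1cc(N2CCNCC2)c2ccccc2o1`, which carries no benzyloxy group, gives 250000 nM. Compound 2 `O=c1cc(N2CCNCC2)c2c(OCc3ccccc3)cccc2o1` gives 429000 nM. Compound 3 `O=c1cc(N2CCNCC2)c2ccc(OCc3ccccc3)cc2o1`, which has its benzyloxy group at a different place on the core, gives 78800 nM, the lowest of the three numbers.

Compound 4 `Cc1c(OCc2ccccc2)ccc2c(N3CCNCC3)cc(=O)oc12` is compound 3 with one further change, methyl in place of hydrogen on an aromatic carbon, ortho to a benzyloxy group. Among the measured compounds shown here, no measured step shows what a methyl does on this core, so the evidence is indirect. For the measured compounds named here, the only steps available are benzyloxy in place of hydrogen on an aromatic carbon. One runs a 1.7-fold higher number from compound 1 to compound 2 (0.23 log units; within the scatter), and the other runs a 3.2-fold lower number from compound 1 to compound 3 (0.50 log units; beyond the scatter). The first lies within the scatter and the second is modest, so even a much larger group than methyl has moved the number only a little here. Neither step gives a direction for a methyl, and no step beyond the scatter is therefore expected. The expected result is a 1.1-fold lower number from compound 3 to compound 4 (0.02 log units; within the scatter). For compound 4 the estimate is 75000 nM, with an expected range from 30000 nM to 190000 nM.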

Compound 4, half-maximal inhibitory concentration: 1100 nM
Beside the measured number, compound 4's estimate is 68-fold (1.83 log units) above it; the measured number lies below the stated range.
By their numbers in this assay, from the lowest: compound 4; then compound 3; then compounds 1 and 2 (each within the scatter of the next).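

In this assay, among the compounds shown here, the single added methyl gives a 72-fold lower number from compound 3 to compound 4 (1.86 log units; beyond the scatter), and this is the first large step on the shared core. The earlier changes, a 1.7-fold higher number from compound 1 to compound 2 (0.23 log units; within the scatter) and a 3.2-fold lower number from compound 1 to compound 3 (0.50 log units; beyond the scatter), brought in a far larger benzyloxy group and moved the number little or modestly, so they gave no sign that one carbon could matter this much on an aromatic carbon ortho to a benzyloxy group, ortho to a fused ring and meta to a fused ring. What lies behind a step of this size cannot be told, since nothing measured here bears on it.

The compounds shown leave open whether a methyl at this place does the same on its own, without the benzyloxy group of compound 3, or whether the large step depends on the two groups being present together. Also open, as far as these compounds go, is whether an ethyl group, a chlorine atom or a hydroxyl group on the same aromatic carbon would lower the number as far, and whether a longer chain in place of the benzyloxy group would keep the low number of compound 4.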